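The compounds below may be only part of what the source reports. "The series", "measured", "known", "first", "only" and "open" are said of these compounds alone.

Working notes on the series. Compound 1 `COc1ccc(-c2cnc(NC(=O)c3ccc(F)cc3)n2C)cc1` carries 4-fluorophenyl on the carbonyl carbon; in a toxicity assay on THP-1 cells (Homo sapiens) for inhibition (on this read-out higher numbers stand for lower toxicity in this test and lower numbers for higher toxicity in this test), compound 1 reports only a limit, >= 50000 nM. Compound 2 `COc1ccc(C(=O)Nc2ncc(-c3ccc(OC)cc3)n2C)cc1` carries 4-methoxyphenyl on that carbon; in this assay compound 2 also reports only a limit, > 100000 nM. Compound 3 `COc1ccc(-c2cnc(NC(=O)C3CCNCC3)n2C)cc1` carries piperidin-4-yl; in this assay compound 3 again reports only a limit, > 100000 nM. Compound 3 thus stands at the edge of what this assay can resolve, and no number separates it from its two neighbours. The steps a step that the two limits leave unreadable from compound 1 to compound 2, a step that the two limits leave unreadable from compound 1 to compound 3 and a step that the two limits leave unreadable from compound 2 to compound 3 are all of unreadable size, since the limit of > 100000 nM in this assay, at which 2 of the 3 values shown sit, and the limit of >= 50000 nM in this assay, at which 1 of the 3 values shown sits, are where every measured value sits.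

Compound 4 `COc1ccc(-c2cnc(NC(=O)c3ccccc3Cl)n2C)cc1` differs from compound 3 by 2-chlorophenyl in place of piperidin-4-yl on a carbonyl carbon. For the measured compounds named here, the steps that bear on it, a step that the two limits leave unreadable from compound 1 to compound 3 and a step that the two limits leave unreadable from compound 2 to compound 3, each exchange a substituted phenyl on the carbonyl carbon for the piperidin-4-yl and each stays unreadable, with both ends at limits. Going by the values given here, nothing among the measured compounds points to the 2-chlorophenyl leaving the limit region in this assay. Compound 4 is expected to give 100000 nM in this assay, between 50000 nM and 200000 nM. The expected step of a number no higher from compound 3 to compound 4 (the limit leaves the size open) is none beyond the scatter, and a limit rather than a number is the likely outcome.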

Compound 4, half-maximal cytotoxic concentration: > 50000 nM
Compound 4: a limit, no number; the forecaster's own chance of this, stated with the estimate: 85%; the middle value is on the limit's open side.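

For the compounds shown here, compound 1, compound 2, compound 3 and compound 4 all report only limits in this assay, and no step among them can be read. It remains open whether any group on the carbonyl carbon, 2-chlorophenyl included, changes the half-maximal cytotoxic concentration, and at what concentration any of these compounds would give a number.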